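This account rests on a few compounds, and the source may have more. Where it says the series, first, only, none or still open, it means among the compounds named here.

Measured in a physicochemical assay for solubility, in phosphate buffer, at pH 7.4; a lower number here means a less soluble compound, a higher number a more soluble compound:
- compound 1 `CC(C)n1cc(-c2ccnc3[nH]c(C4CCN(CC(=O)N(C)C)CC4)cc23)ccc1=O`: 110000 nM
- compound 2 `CCn1cc(-c2ccnc3[nH]c(C4CCN(CC(=O)N(C)C)CC4)cc23)ccc1=O`: > 1000000 nM

Compound 2 gives > 1000000 nM, which is a limit of this assay and not a number.

Compound 3 `COc1cc(=O)n(C)cc1-c1ccnc2[nH]c(C3CCN(CC(=O)N(C)C)CC3)cc12` differs from compound 2 by one swap: a group of 10 heavy atoms (7 carbon, 1 nitrogen, 2 oxygen; one six-membered aromatic ring with 1 hetero atom) in place of a group of 9 heavy atoms (7 carbon, 1 nitrogen, 1 oxygen; one six-membered aromatic ring with 1 hetero atom), on an aromatic carbon. The swap sits on an aromatic carbon of a six-membered aromatic ring with 1 nitrogen, opposite the ring nitrogen.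

Among the compounds with values here, only one measured step bears on it: an at least 9.0-fold higher number from compound 1 to compound 2 (0.95 log units; beyond the scatter). That step lies beyond the scatter and changes the same group, so a modest drop to a lower number in this assay is expected. The expected change is an at least 2.2-fold lower number from compound 2 to compound 3 (0.34 log units; beyond the scatter).

For compound 3 the estimate is 450000 nM, with an expected range of 120000 nM to 1000000 nM.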

Compound 3, solubility: 670000 nM
Beside the measured number, compound 3's estimate is 1.5-fold (0.17 log units) below it; low and high end bracket the measured number.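

Within the data shown here, compound 3 is the first to alter the ring group on this aromatic carbon beyond the chain on its nitrogen, and in this assay the result is an at least 1.4-fold lower number from compound 2 to compound 3 (0.17 log units; that floor lies within the scatter). From the compounds shown here alone, the true size of this step stays unknown because compound 2 gives a value that is a limit of the assay, not a number: the limit of > 1000000 nM in this assay, at which 1 of the 3 values shown sits. Set against the group of compound 1, the new group gives a 6.1-fold higher number from compound 1 to compound 3 (0.78 log units; beyond the scatter).

Going by these compounds, how far compound 3 really lies from compound 2 remains open. So does the effect of a different group on this ring, such as an amine or a carboxylic acid.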